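A few compounds are considered here, and "the series" means these few. Any claim that something is new, unique, unknown or untested is made for them only; others in the source may bear on it.

Working notes on the series in a functional assay on A2780 cells (Homo sapiens) for antiproliferative activity; a lower number here means a stronger inhibitor, a higher number a weaker inhibitor: compound 1 (`Cc1ccc2c(c1C)CN(CCCN)CC2c1ccccc1`) gives 2420 nM and compound 2 (`Cc1ccc2c(c1C)CN(CCCN(C)C)CC2c1ccccc1`) gives 3240 nM, while compound 3 (`COC(=O)N1Cc2c(ccc(C)c2C)C(c2ccccc2)C1`) offers no number, its entry reading "not determined" (no result reported). Compound 4 (`Cc1ccc2c(c1C)CN(C(=O)N1CCCCC1)CC2c1ccccc1`) follows from compound 3 by piperidin-1-yl in place of methoxy on a carbonyl carbon. Among the measured compounds shown here, the only measured step, a 1.3-fold higher number from compound 1 to compound 2 (0.13 log units; within the scatter), lies within the scatter and concerns a chain amine, not this carbonyl. It therefore bears only loosely on the change, and with no starting value for compound 3, no step size or direction can be expected. The level of compound 1 at 2420 nM serves as a rough anchor, with wide uncertainty. For compound 4 the estimated value is 5000 nM, with an expected range from 1500 nM to 20000 nM.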

Compound 4, half-maximal inhibitory concentration: 2830 nM
Estimate against measurement, compound 4: 1.8-fold (0.25 log units) above; measured number inside the range.
By their numbers in this assay, from the lowest: compounds 1, 4 and 2 (each within the scatter of the next).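

In this assay, with (piperidin-1-yl)carbonyl in place of either chain on the amine nitrogen in a ring, the steps of a 1.1-fold lower number from compound 2 to compound 4 (0.06 log units; within the scatter) and a 1.2-fold higher number from compound 1 to compound 4 (0.07 log units; within the scatter) both lie within the scatter. A terminal chain amine is therefore not required to hold this level among these three compounds. The change from methoxy to piperidin-1-yl on the carbonyl carbon itself cannot be read, since compound 3 has no number. No measurement on hand accounts for this result. Open, on these data alone, is whether a pyrrolidin-1-yl or morpholin-4-yl group on the carbonyl carbon would keep this level. Also open, as far as these compounds go, is whether a carboxylic acid or a longer chain on the ring nitrogen would move the number beyond the scatter.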